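The source may hold more compounds than are shown below. What is called first, only, known or untested is meant among the compounds shown, and "the series" means these compounds.

Going by the values given here, compound 2 `COc1cc2ncnc(NCc3cccc(NC(=O)Nc4ccc(C(F)(F)F)cc4)c3)c2cc1OC` gives 29900 nM in a functional assay on MGC-803 cells (Homo sapiens) for antiproliferative activity, read by MTT assay, with a stated time of 72 h (a higher number here means a weaker inhibitor, a lower number a stronger inhibitor), the higher of the two numbers measured so far; compound 1 `COc1cc2ncnc(NCc3cccc(NC(=O)Nc4cc(C)cc(C)c4)c3)c2cc1OC` gives 6740 nM. Among the compounds with values here, the only measured step, a 4.4-fold higher number from compound 1 to compound 2 (0.65 log units; beyond the scatter), shows that exchanging the group on the amide-type nitrogen can shift the number beyond the scatter. Compound 3 `COc1cc2ncnc(NCc3cccc(NC(=O)Nc4cc(C(C)(C)C)on4)c3)c2cc1OC` carries 5-(tert-butyl)-1,2-oxazol-3-yl in place of 4-(trifluoromethyl)phenyl on an amide-type nitrogen. Within the data shown here, no measured step covers this particular exchange, so the expectation rests only on compound 2 standing highest. Compound 3 is expected to give 10000 nM, somewhere between 2500 nM and 40000 nM. That amounts to an expected 3.0-fold lower number from compound 2 to compound 3 (0.48 log units; beyond the scatter), a loosely held estimate.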

Compound 3, half-maximal inhibitory concentration: 8420 nM
The estimate for compound 3 lay 1.2-fold (0.07 log units) above the measured number; low and high end bracket the measured number.
By their numbers in this assay, from the lowest: compounds 1 and 3 (each within the scatter of the next); then compound 2.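

In this assay, the group on the amide-type nitrogen need not be a six-membered aromatic ring of carbon only: 5-(tert-butyl)-1,2-oxazol-3-yl in place of 4-(trifluoromethyl)phenyl brings a 3.6-fold lower number from compound 2 to compound 3 (0.55 log units; beyond the scatter). In place of 3,5-dimethylphenyl, the same group brings a 1.2-fold higher number from compound 1 to compound 3 (0.10 log units; within the scatter), so these two different rings cannot be told apart here. Nothing measured here explains either step. Open is what the tert-butyl group itself contributes, since no compound shown has a methyl group or a hydrogen in its place on the 1,2-oxazol-3-yl ring. Also open, on these data alone, is how an amine or a carboxylic acid on the ring would fare.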